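Swapping a Carboxy Group for Hydroxymethyl in Compound 1

The source may hold more compounds than are shown below. What is called first, only, known or untested is meant among the compounds shown, and "the series" means these compounds.

Compound 1 `COc1cccc2cc(C(=O)NCC(=O)O)c(=O)oc12` was tested in an assay on HEK293 cells for displacement of a labelled ligand from adenosine receptor A2b (Homo sapiens), read by scintillation counting, with a stated time of 30 min, tested at 10 uM; a higher number here means more inhibition at the concentration tested (going by the name of the read-out), a lower number less inhibition. In this assay compound 1 gives 35%. Among the plain numbers shown, compound 1 stands highest of two; its nearest neighbour, compound 3 `O=C(O)CNC(=O)c1cc2ccccc2oc1=O`, gives 9%. Among the measured compounds shown here, the only single-point step measured so far runs a number 26 percentage points lower from compound 1 to compound 3 (beyond the scatter). Compound 2 `COc1cccc2cc(C(=O)NC3CCCCC3)c(=N)oc12` sits at the limit described by the limit of > 70% in this assay, at which 1 of the 3 values shown sits, and for compound 2 the value > 70% is a limit of the assay rather than a number.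

Compound 4 `COc1cccc2cc(C(=O)NCCO)c(=O)oc12` has not yet been measured in this assay. It differs from compound 1 by hydroxymethyl in place of carboxy on a saturated chain carbon bound to an amide-type nitrogen. For the measured compounds named here, the measured step of a number 26 percentage points lower from compound 1 to compound 3 (beyond the scatter) concerns the methoxy group on the aromatic carbon, not the chain carrying the carboxy, so it does not bear directly on this change; no measured pair shows what happens when the carboxy leaves and hydroxymethyl enters. Without such a pair, the expectation for compound 4 is a step of modest size or none beyond the scatter, with a wide range to either side. Compound 4 is therefore expected to give 35%, between 15% and 60%, which means an expected step of no change at the digits printed from compound 1 to compound 4 (within the scatter).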

Compound 4, a percentage reported as inhibition, at one concentration (the size of the read-out at that concentration, not a potency): 7%
Beside the measured number, compound 4's estimate is 28 percentage points above it, outside the stated range (below it).
By their numbers in this assay, from the lowest: compounds 4 and 3 (each within the scatter of the next); then compound 1. At a limit, above all of these: compound 2.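

The end of the side chain is not a place where a swap passes unnoticed in this assay, since the change gives a number 28 percentage points lower from compound 1 to compound 4 (beyond the scatter). Among the compounds shown here, until now the only single change that could be read was a number 26 percentage points lower from compound 1 to compound 3 (beyond the scatter), on the aromatic carbon, so this is the first reading on the chain, and it shows that the number for compound 1 depends on the chain end as well as on the methoxy group. The carboxy and hydroxymethyl groups match in their counts of hydrogen-bond donors and acceptors and neither carries a net charge, so those counts do not separate them; the carboxy group has a double bond that the hydroxymethyl group lacks, but nothing measured here gives a reason for the step.

From the compounds shown here alone, whether another group at this chain end, such as an amine, a methyl ester or a primary amide, or a longer chain, would hold or raise the number remains open. Also open, going by these compounds, is how the chain end behaves when the aromatic carbon carries something other than methoxy, such as chlorine or ethoxy.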